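This account rests on a few compounds, and the source may have more. Where it says the series, first, only, none or still open, it means among the compounds named here.

Compound 1 `O=C(O)CCCSCCN1C(=O)CC[C@@H]1/C=C/[C@@H](O)Cc1cccc(N2Cc3ccccc3C2)c1` and compound 2 `O=C(O)CCCSCCN1C(=O)CC[C@@H]1/C=C/[C@@H](O)Cc1cccc(-c2nc3ccccc3s2)c1` share the same core and differ only in the two-ring group attached to one aromatic carbon. In an assay on CHO cells for displacement of a labelled ligand from prostaglandin E2 receptor EP1 subtype (Mus musculus), read by scintillation counting, with a stated time of 20 min (on this read-out higher numbers stand for weaker inhibition and lower numbers for stronger inhibition), compound 1 gives 7100 nM. In this assay compound 2 reaches only the limit of > 10000 nM, so no number is known for it, and it stands at the limit of > 10000 nM in this assay, at which 1 of the 2 values shown sits. The measured step of an at least 1.4-fold higher number from compound 1 to compound 2 (0.14 log units; that floor lies within the scatter) is therefore at best a small weakening, and its floor lies within the scatter. Compound 3 `O=C(O)CCCSCCN1C(=O)CC[C@@H]1/C=C/[C@@H](O)Cc1cccc(-c2cc3ccccc3o2)c1` carries the next change at the same place: 1-benzofuran-2-yl in place of 1,3-benzothiazol-2-yl on an aromatic carbon. Among the compounds with values here, only one measured step bears on this swap, the one from compound 1 to compound 2, and it showed no clear effect for exchanging one two-ring group for another there. Compound 2 gives only a limit. The expected step of a number no higher from compound 2 to compound 3 (the limit leaves the size open) is therefore taken as no change beyond the scatter, with compound 3 expected to stay weak like compound 1. Compound 3 is thus estimated at 10000 nM, within a range from 3000 nM to 30000 nM, and this assay may again report only a limit.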

Compound 3, inhibition constant: > 10000 nM
Compound 3 was reported as a limit; the forecaster's own chance of this, stated with the estimate: 50%; the middle value sits exactly at the limit.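

In this assay compound 3 gives only a limit, not a number, so swapping 1,3-benzothiazol-2-yl for 1-benzofuran-2-yl adds a second aromatic two-ring group at this place without any readable effect of its own. The step between compound 2 and compound 3 cannot be read, because both compounds sit at the same reading: the limit of > 10000 nM in this assay, at which 2 of the 3 values shown sit. As far as these compounds go, what the result does add is a second comparison with compound 1, an at least 1.4-fold higher number from compound 1 to compound 3 (0.14 log units; that floor lies within the scatter), so replacing the non-aromatic five-membered ring of compound 1 with a different aromatic one again gives no clear weakening, although the true size of the step remains unknown.

The compounds shown leave open how much weaker than the limit compound 2 and compound 3 really are, and whether the change from sulfur and nitrogen to oxygen in the five-membered ring matters at all. They also leave open whether a smaller group at this place, such as a plain phenyl ring or a methoxy group, would give a clearly lower number.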